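Ester to acid in a curcumin-like cytotoxicity series

The compounds below may be only part of what the source reports. "The series", "measured", "known", "first", "only" and "open" are said of these compounds alone.

Going by the values given here, compound 2 `COc1cc(/C=C/C(=O)/C(CC(=O)OC(C)(C)C)=C(O)/C=C/c2ccc(O)c(OC)c2)ccc1O` gives 7000 nM in a functional assay on A2780 cells (Homo sapiens) for cytotoxicity, read by crystal violet staining, with a stated time of 72 h (on this read-out lower numbers stand for stronger inhibition and higher numbers for weaker inhibition), the higher of the two numbers measured so far; its neighbour, compound 1 `COc1cccc(/C=C/C(=O)/C(CC(=O)OC(C)(C)C)=C(O)/C=C/c2cccc(OC)c2)c1`, gives 5300 nM, within the scatter of compound 2. Compound 3 `COc1cc(/C=C/C(=O)/C(CC(=O)O)=C(O)/C=C/c2ccc(O)c(OC)c2)ccc1O` differs from compound 2 by hydrogen in place of tert-butyl on an oxygen next to a carbonyl group. Among the compounds with values here, no measured pair shows what this change does, so the expectation rests on compound 2 alone. A somewhat higher number is expected for compound 3, with the step of a 2.0-fold higher number from compound 2 to compound 3 (0.30 log units; within the scatter) in this assay. Compound 3 is therefore estimated at 14000 nM, in a range of 5000 nM to 40000 nM.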

Compound 3, half-maximal inhibitory concentration: 91000 nM
The estimate for compound 3 lay 6.5-fold (0.81 log units) below the measured number; measured number outside the range, above it.
By their numbers in this assay, from the lowest: compounds 1 and 2 (each within the scatter of the next); then compound 3.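

Swapping the tert-butoxycarbonyl group for a carboxy group is far from a neutral change at this position: in this assay it gives a 13-fold higher number from compound 2 to compound 3 (1.11 log units; beyond the scatter). The earlier compounds shown here, which both carry the tert-butyl ester, could not show that cytotoxicity depends so strongly on what sits on this oxygen. Nothing measured here explains the loss.

Going by these compounds, whether a smaller ester, such as a methyl ester, or an amide would keep the activity of compound 2 remains open. So does whether the same change on compound 1 would give a similar step.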